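This account rests on a few compounds, and the source may have more. Where it says the series, first, only, none or still open, it means among the compounds named here.

Measured in a functional assay on SiHa cells (Homo sapiens) for inhibition; on this read-out lower numbers stand for stronger inhibition and higher numbers for weaker inhibition:

Compound 1 (`COc1cc(/C=C/C(=O)c2cccc(NC(=O)c3cc(Cl)cc(Cl)c3)c2)ccc1O`) gives 17.7 ug/mL
Compound 2 (`COc1cc(/C=C/C(=O)c2cccc(N)c2)ccc1O`) gives 12.3 ug/mL

Compound 2 and compound 1 lie within the scatter of each other, so compound 2 does not stand apart. Compound 3 (`COC(=O)C(=O)Nc1cccc(C(=O)/C=C/c2ccc(O)c(OC)c2)c1`) carries (methoxycarbonyl)carbonyl in place of hydrogen on a nitrogen on an aromatic ring. Among the measured compounds shown here, one measured step bears on this, the loss of (3,5-dichlorophenyl)carbonyl from such a nitrogen (a 1.4-fold lower number from compound 1 to compound 2 (0.16 log units; within the scatter)). It stays within the scatter, so no step beyond the scatter is expected in this assay, though a single step with a different group is thin support. The expected step is small (a 1.2-fold higher number from compound 2 to compound 3 (0.09 log units; within the scatter)). Compound 3 is expected at 15 ug/mL, with an estimated range of 7 ug/mL to 30 ug/mL.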

Compound 3, half-maximal inhibitory concentration: 7.71 ug/mL
The estimate for compound 3 lay 1.9-fold (0.29 log units) above the measured number; measured number inside the range.
By their numbers in this assay, from the lowest: compounds 3, 2 and 1 (each within the scatter of the next, the first and the last beyond it).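

In this assay, (methoxycarbonyl)carbonyl on the nitrogen on an aromatic ring gives a 1.6-fold lower number from compound 2 to compound 3 (0.20 log units; within the scatter) and so does not separate from the free amino compound. Among the compounds shown here, replacing 3,5-dichlorophenyl with methoxycarbonyl on the carbonyl carbon gives a 2.3-fold lower number from compound 1 to compound 3 (0.36 log units; beyond the scatter) and is the first step beyond the scatter, though a modest one. The group on that carbonyl carbon can therefore shift the number, at least between these two amides.

Going by these compounds, whether a carboxylic acid in place of the methyl ester, or a longer alkyl chain on that carbonyl, would extend the shift remains open. Nothing available accounts for the difference between these amides.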